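A few compounds are considered here, and "the series" means these few. Any claim that something is new, unique, unknown or untested is made for them only; others in the source may bear on it.

Of the compounds shown here, two have been tested in a functional assay on HepG2 cells (Homo sapiens) for cytotoxicity, read by MTT assay, with a stated time of 48 h (a higher number here means a weaker inhibitor, a lower number a stronger inhibitor), so far. Compound 1 `CC1=NN(C(=O)CCc2ccccc2)C(c2cc(Br)ccc2O)C1` gives 17900 nM in this assay. Compound 2 `Cc1ccc(C(=O)N2N=C(c3cc4ccccc4oc3=O)CC2c2ccccc2)cc1` gives 52300 nM in this assay, the highest of the two numbers, and the gap to compound 1, its nearest neighbour, lies beyond the usual scatter of repeated measurements. The two compounds share no single-point difference, so nothing can be read from their pair about one change in isolation.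

The next compound, compound 3 `O=C(CN1CCCC1)N1N=C(c2cc3ccccc3oc2=O)CC1c1ccccc1`, keeps the core of compound 2 and changes only the group attached to the carbonyl carbon whose other neighbour is the amide-type nitrogen in the ring: (pyrrolidin-1-yl)methyl in place of 4-methylphenyl on a carbonyl carbon. For the measured compounds named here, no measured pair shows what such a swap does in this assay, so the expectation rests on compound 2 alone.

The step from compound 2 to compound 3 is expected to be small and slightly downward, a 1.3-fold lower number from compound 2 to compound 3 (0.12 log units; within the scatter), within or close to the scatter. Compound 3 is therefore estimated at 40000 nM, with a range from 15000 nM to 110000 nM.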

Compound 3, half-maximal inhibitory concentration: 44300 nM
Compound 3: middle estimate off by 1.1-fold (0.04 log units), on the low side, within the range that was stated.
By their numbers in this assay, from the lowest: compound 1; then compounds 3 and 2 (each within the scatter of the next).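

For the compounds shown here, replacing 4-methylphenyl with (pyrrolidin-1-yl)methyl on a carbonyl carbon whose other neighbour is an amide-type nitrogen in a ring gives the first single-change comparison: a 1.2-fold lower number from compound 2 to compound 3 (0.07 log units; within the scatter) in this assay. Compound 2 and compound 3 therefore cannot be told apart here, even though the swap exchanges a six-membered aromatic ring of carbon only for a five-membered non-aromatic ring with a hetero atom and adds a hydrogen-bond acceptor to the count. Nothing measured alongside these numbers offers an explanation for this result.

Going by these compounds, it remains open whether any group at this carbonyl carbon would separate from these two, for example a short alkyl chain such as ethyl, a (morpholin-4-yl)methyl group, or a chain ending in a carboxylic acid. Compound 1 differs from compound 2 and compound 3 in more than one place, so the series does not yet show which structural feature, if any, accounts for its separate position in the ranking.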